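The source may hold more compounds than are shown below. What is called first, only, known or untested is meant among the compounds shown, and "the series" means these compounds.

Working notes on the series. In a functional assay on MDA-MB-231 cells (Homo sapiens) for inhibition, with a stated time of 48 h (a higher number here means that more compound is needed for the effect, a lower number that less compound is needed), compound 1 (`CN[C@@H](C)C(=O)N[C@@H](CCCCNC(=O)Nc1ccc(Oc2ccc(NC(=O)NCCCC[C@H](NC(=O)[C@H](C)NC)C(=O)N3CCC[C@H]3C(=O)NC(c3ccccc3)c3ccccc3)cc2)cc1)C(=O)N1CCC[C@H]1C(=O)NC(c1ccccc1)c1ccccc1`) gives 14400 nM as its half-maximal effective concentration. Compound 2 (`CN[C@@H](C)C(=O)N[C@@H](CSSC(C)(C)C)C(=O)N1CCC[C@H]1C(=O)NC(c1ccccc1)c1ccccc1`) gives 49900 nM on the same read-out. This is the higher of the two numbers, and the gap to compound 1 lies beyond the usual scatter, so compound 2 stands at the weak end of what has been measured so far.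

The next entry is compound 3 (`CN[C@@H](C)C(=O)N[C@@H](CCCCN)C(=O)N1CCC[C@H]1C(=O)NC(c1ccccc1)c1ccccc1`), which has no number yet. Its difference from compound 2 is 3-aminopropyl in place of ((tert-butyl)sulfanyl)sulfanyl on a saturated chain carbon, two bonds along the chain from an amide-type nitrogen and a carbonyl carbon in total: 3-aminopropyl in place of ((tert-butyl)sulfanyl)sulfanyl on a saturated chain carbon, two bonds along the chain from an amide-type nitrogen and a carbonyl carbon.

For the measured compounds named here, no measured pair differs in one place only, so the data give no direct guide to this change. The expectation therefore stays close to compound 2 at 49900 nM with a wide margin on both sides. The expected move is a 1.1-fold lower number from compound 2 to compound 3 (0.04 log units; within the scatter) in this assay terms, which means no step beyond the scatter in either direction. For compound 3 the estimated value is 45000 nM (expected range 14000 nM to 100000 nM).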

Compound 3, half-maximal effective concentration: > 100000 nM
Compound 3: no number, only a limit; the forecaster's own chance of this, stated with the estimate: 25%; at least 2.2-fold (0.34 log units) between middle value and limit.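

In this assay compound 3 gives no number, only a limit of the assay: the limit of > 100000 nM in this assay, at which 1 of the 3 values shown sits.

For the compounds shown here, this is the first reading of any change on the saturated chain carbon, two bonds along the chain from an amide-type nitrogen and a carbonyl carbon: 3-aminopropyl in place of ((tert-butyl)sulfanyl)sulfanyl gives an at least 2.0-fold higher number from compound 2 to compound 3 (0.30 log units; that floor lies within the scatter). On these data alone, the step is only a floor, and as that floor lies within the scatter, it does not by itself establish a real difference; it does show that 3-aminopropyl brings no gain over ((tert-butyl)sulfanyl)sulfanyl here, and how far the true gap extends remains unknown.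

The compounds shown do not separate the contribution of the terminal amine from that of the departing pair of sulfur atoms and the tert-butyl group. A plain butyl chain or a chain ending in a carboxylic acid at the same place, or a smaller ethyl group on the sulfur pair, would be needed to tell these apart in this assay.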